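A New Leaving Group on a Weakly Active Series

The source may report more compounds than this note shows. Statements on the series, on what has been measured and on what is new or still open speak of the compounds shown alone.

Compound 1 `CC(C)[C@H](NC(=O)COc1cccc2ccccc12)C(=O)N[C@@H](CC(=O)O)C(=O)CSC1=NCCS1` in a functional assay on Jurkat cells (Homo sapiens) for inhibition (a higher number here means a weaker inhibitor, a lower number a stronger inhibitor), gives only the limit > 200000 nM.
Compound 2 `CC(C)[C@H](NC(=O)COc1cccc2ccccc12)C(=O)N[C@@H](CC(=O)O)C(=O)CSc1nc(-c2ccccc2)c(-c2ccccc2)o1` gives only the limit > 200000 nM.
Compound 3 `CC(C)[C@H](NC(=O)COc1cccc2ccccc12)C(=O)N[C@@H](CC(=O)O)C(=O)CSc1nnnn1-c1ccccc1` gives 153000 nM.

Compound 3 is thus the only one of the three with a number in this assay; the other two sit at a limit, as shown by the limit of > 200000 nM in this assay, at which 2 of the 3 values shown sit. Among the compounds with values here, the single step between measured compounds that differ in one place, an at least 1.3-fold lower number from compound 1 to compound 3 (0.11 log units; that floor lies within the scatter), is within the scatter, so the series so far shows no change beyond it.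

Compound 4 `CC(C)[C@H](NC(=O)COc1cccc2ccccc12)C(=O)N[C@@H](CC(=O)O)C(=O)COc1nccc(C(F)(F)F)n1` differs from compound 3 by (4-(trifluoromethyl)pyrimidin-2-yl)oxy in place of (1-phenyl-1H-tetrazol-5-yl)sulfanyl on a saturated chain carbon bound to a carbonyl carbon. Within the data shown here, no measured step bears on this exchange: the one step that exists concerns a different group on a sulfur, and it did not move the number beyond the scatter. Compound 4 is therefore expected to stay near compound 3, with an expected step of a 1.0-fold lower number from compound 3 to compound 4 (0.01 log units; within the scatter) of no size beyond the scatter. Compound 4 is estimated at 150000 nM, between 50000 nM and 500000 nM, and a limit rather than a number remains a real possibility, given that compound 1 and compound 2 gave only limits.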

Compound 4, half-maximal inhibitory concentration: > 200000 nM
Compound 4 gave a limit, no number; the forecaster's own chance of this, stated with the estimate: 45%; middle value at least 1.3-fold (0.12 log units) from the limit.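

Exchanging the sulfur-linked tetrazole for the oxygen-linked pyrimidine on a saturated chain carbon bound to a carbonyl carbon gives an at least 1.3-fold higher number from compound 3 to compound 4 (0.11 log units; that floor lies within the scatter), so no loss beyond the scatter is shown. The step from compound 1 to compound 4 cannot be read, since both values are limits. Compound 4 is the only compound shown with an oxygen on this carbon, and this change of linking atom and ring also yields no number, only the limit already reached by the sulfur-linked compound 1 and compound 2: the limit of > 200000 nM in this assay, at which 3 of the 4 values shown sit.

As far as these compounds go, how far compound 1, compound 2 and compound 4 lie beyond that limit stays open, and with it whether any of them truly differs from compound 3. Also open, from the compounds shown here alone, is whether a phenoxy group on the same carbon would give a number in this assay.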